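The compounds below may be only part of what the source reports. "The series", "measured", "known", "first", "only" and "open" are said of these compounds alone.

Compound 1 `C#Cc1cn([C@@H]2O[C@H](CO)[C@@H](O)[C@H]2O)c2nc(N)nc(OC)c12` and compound 2 `COc1nc(N)nc2c1c(-c1ccoc1)cn2[C@@H]1O[C@H](CO)[C@@H](O)[C@H]1O` share one core and differ at a single aromatic carbon. In a functional assay on A549 cells (Homo sapiens), read by MTT assay, with a stated time of 72 h (a lower number here means a stronger inhibitor, a higher number a weaker inhibitor), compound 1 gives > 100000 nM, which is a limit of the assay and not a number. Compound 2 gives > 20000 nM in this assay, again a limit rather than a number. The step that the two limits leave unreadable from compound 1 to compound 2 is therefore unreadable, since the limit of > 100000 nM in this assay, at which 1 of the 2 values shown sits, and the limit of > 20000 nM in this assay, at which 1 of the 2 values shown sits, are both limits. Among the compounds with values here, compound 2 thus stands at a limit in this assay, and the one other value shown is also a limit.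

Compound 3 `Nc1nc(N)c2c(-c3ccoc3)cn([C@@H]3O[C@H](CO)[C@@H](O)[C@H]3O)c2n1` differs from compound 2 by amino in place of methoxy on an aromatic carbon. Within the data shown here, no measured step bears on this change: the single measured step concerns another position and is itself unreadable between two limits. The expectation rests on compound 2 alone, which sits at a limit in this assay.

Compound 3 is expected to remain weak in this assay, estimated near 30000 nM with a range of 5000 nM to 100000 nM. The step that the limit leaves unreadable from compound 2 to compound 3 implied by this estimate is expected to be small, and a further limit instead of a number is likely.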

Compound 3, half-maximal inhibitory concentration: > 20000 nM
Compound 3: only a limit was reported (the forecaster's own chance of this, stated with the estimate: 70%); the middle value lies beyond the limit too.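

In this assay compound 3 gives > 20000 nM which is a limit and not a number. Compound 2 also stands at a limit, so no step can be read between compound 2 and compound 3. The compounds shown leave open what actual strength compound 1, compound 2 and compound 3 have in this assay beyond their limits.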